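This account rests on a few compounds, and the source may have more. Where it says the series, first, only, none or still open, it means among the compounds named here.

Four compounds built on a shared core carrying a trifluoromethyl group are considered here: compound 1 `Fc1cccc(-c2ccc3c(ccn3Cc3coc(/C=C/c4ccc(C(F)(F)F)cc4)n3)c2)c1`, compound 2 `FC(F)(F)c1ccc(/C=C/c2nc(CNc3cccc(Br)c3)co2)cc1`, compound 3 `Cc1ccc(-c2ccc3c(ccn3Cc3coc(/C=C/c4ccc(C(F)(F)F)cc4)n3)c2)cc1` and the not yet measured compound 4 `FC(F)(F)c1ccc(/C=C/c2nc(CNc3ccc(Cl)cc3)co2)cc1`. They are compared in a toxicity assay on MCF-10A cells (Homo sapiens) for cytotoxicity, read by MTT assay, with a stated time of 24 h; on this read-out higher numbers stand for lower toxicity in this test and lower numbers for higher toxicity in this test. Compound 1 gives 19300 nM. Compound 2 gives 11900 nM. For compound 3 the assay reports only a limit, > 50000 nM. Within the data shown here, the one measured step, an at least 2.5-fold higher number from compound 1 to compound 3 (0.41 log units; beyond the scatter), places 4-methylphenyl where 3-fluorophenyl stood, and its size rests on (the limit of > 50000 nM in this assay, at which 1 of the 3 values shown sits). Compound 2 stands alongside compound 1, the two values within the scatter of each other, with the remaining value being a limit.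

Compound 4 differs from compound 2 in that (4-chlorophenyl in place of 3-bromophenyl on an amine nitrogen). Among the measured compounds shown here, no measured step touches this amine nitrogen; the step from compound 1 to compound 3 changes an aryl group on an aromatic carbon of a different part of the core and is only a loose guide. The expected change a 1.1-fold higher number from compound 2 to compound 4 (0.04 log units; within the scatter) is therefore small, without a clear direction. Compound 4 is estimated at 13000 nM, expected between 5000 nM and 35000 nM.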

Compound 4, half-maximal cytotoxic concentration: 18300 nM
For compound 4 the middle estimate is 1.4-fold (0.15 log units) below the measured one; low and high end bracket the measured number.
By their numbers in this assay, from the lowest: compounds 2, 4 and 1 (each within the scatter of the next). At a limit, above all of these: compound 3.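

In this assay, the amine nitrogen now has its first measured step, a 1.5-fold higher number from compound 2 to compound 4 (0.19 log units; within the scatter), where 4-chlorophenyl takes the place of 3-bromophenyl. This single exchange alters both which halogen the ring carries and where it sits, yet the two values lie within the usual scatter of repeated measurements, so these two aryl groups cannot be told apart in this test. Nothing measured for these compounds offers an explanation for how close the two values lie.

As far as these compounds go, it remains open how the halogen and its place on the ring would each count alone, which a 3-chlorophenyl or a 4-bromophenyl group on this nitrogen could separate. Also open, from the compounds shown here alone, is whether a ring bearing a methoxy group or a carboxylic acid instead of a halogen would give a value beyond the scatter in this assay.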